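The source may report more compounds than this note shows. Statements on the series, on what has been measured and on what is new or still open speak of the compounds shown alone.

Working notes on the series. Compound 1 `COc1ccc(-c2cn(Cc3ccccc3)nn2)cc1`, compound 2 `Cc1ccc(-c2cn(Cc3ccccc3)nn2)cc1` and compound 3 `C1=C(c2cn(Cc3ccccc3)nn2)CCCC1` share one core, as does the not yet measured compound 4 `CCCCc1cn(Cc2ccccc2)nn1`. In a functional assay on NUGC-3 cells (Homo sapiens) for antiproliferative activity, read by MTT assay, with a stated time of 72 h (on this read-out lower numbers stand for stronger inhibition and higher numbers for weaker inhibition), compound 1 gives 158000 nM. In this assay compound 2 gives 129000 nM. Among the measured compounds shown here, the only step between measured neighbours, a 1.2-fold lower number from compound 1 to compound 2 (0.09 log units; within the scatter), stays within the scatter, so those two compounds cannot be told apart on this read-out. For compound 3 this assay reports no number but only a limit, > 100000 nM. Compound 3 therefore stands at the limit of > 100000 nM in this assay, at which 1 of the 3 values shown sits, and against compound 1 and compound 2 its value shows only that it is not inside their range.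

The change under study is butyl in place of cyclohex-1-en-1-yl on an aromatic carbon. For the measured compounds named here, the one measured step does not touch this kind of change: it swaps methyl for methoxy at another place and is itself within the scatter, so it offers no reading on the direction of a ring-to-chain swap. Nothing measured points to a step beyond the scatter in this assay, and the expected step is a step that the limit leaves unreadable from compound 3 to compound 4. Compound 4 is estimated at 150000 nM, with a range from 60000 nM to 400000 nM, and a limit rather than a number is the likelier outcome.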

Compound 4, half-maximal inhibitory concentration: > 100000 nM
Compound 4: only a limit was reported; the forecaster's own chance of this, stated with the estimate: 60%; the middle value is on the limit's open side.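

Compound 3 and compound 4 each carry only a limit and not a number, so no step can be read between them: the limit of > 100000 nM in this assay, at which 2 of the 4 values shown sit.

The compounds shown leave open whether butyl in place of cyclohex-1-en-1-yl on an aromatic carbon moves the antiproliferative read-out in either direction, and by how much.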